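Chloro on the benzyloxy ring: compound 3 to compound 4

The source may report more compounds than this note shows. Statements on the series, on what has been measured and on what is new or still open speak of the compounds shown alone.

The series shares one core; the compounds differ at the aryl on the core and at the benzyloxy side of the amide. Compound 1 `Cc1ccc(-c2nn(-c3ccccc3)cc2C(=O)NOCc2ccccc2Cl)cc1` carries a methyl on the aryl and a 2-chlorobenzyl group; in a functional assay on A549 cells (Homo sapiens) for antiproliferative activity, read by MTT assay, with a stated time of 48 h, in the presence of a further agent that is not named here (a lower number here means a stronger inhibitor of growth, a higher number a weaker inhibitor of growth), compound 1 gives 380 nM. Within the data shown here, compound 2 `COc1ccc(-c2nn(-c3ccccc3)cc2C(=O)NOCc2ccccc2Cl)cc1` gives 2450 nM; the step of a 6.4-fold higher number from compound 1 to compound 2 (0.81 log units; beyond the scatter) is the only single-place step measured. Compound 3 `O=C(NOCc1ccccc1)c1cn(-c2ccccc2)nc1-c1ccc(Cl)cc1` carries a chloro on the aryl and a plain benzyl group and gives 13000 nM, the highest number of the three, with compound 2 nearest and compound 1 furthest.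

Compound 4 `O=C(NOCc1ccccc1Cl)c1cn(-c2ccccc2)nc1-c1ccc(Cl)cc1` differs from compound 3 by chloro in place of hydrogen on an aromatic carbon. Among the measured compounds shown here, no measured step bears on this change directly: compounds 1 and 2 both carry the 2-chlorobenzyl group and give lower numbers than compound 3, but each also differs from compound 3 at the aryl, so their gaps cannot be assigned to the chloro alone. The measured step from compound 1 to compound 2 concerns the aryl and says nothing about the benzyl side. On the weak hint from compounds 1 and 2, a lower number than compound 3 is expected for compound 4, a modest step of a 3.7-fold lower number from compound 3 to compound 4 (0.57 log units; beyond the scatter) with wide uncertainty. Compound 4 is estimated at 3500 nM, between 900 nM and 14000 nM.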

Compound 4, concentration for 50% growth inhibition: 15500 nM
Estimate against measurement, compound 4: 4.4-fold (0.65 log units) below, and the stated range ends below it.
By their numbers in this assay, from the lowest: compound 1; then compound 2; then compounds 3 and 4 (each within the scatter of the next).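

In this assay, compounds 3 and 4 read alike, with a 1.2-fold higher number from compound 3 to compound 4 (0.08 log units; within the scatter), so with chloro on the aryl, the change from benzyl to 2-chlorobenzyl gives no separation beyond the scatter. With the 2-chlorobenzyl group held fixed, the aryl substituent does separate the compounds: chloro in place of methoxy gives a 6.3-fold higher number from compound 2 to compound 4 (0.80 log units; beyond the scatter), and chloro in place of methyl gives a 41-fold higher number from compound 1 to compound 4 (1.61 log units; beyond the scatter), so the low numbers of compounds 1 and 2 cannot be credited to the 2-chlorobenzyl group alone. Nothing available explains why the aryl substituent separates these compounds while the chloro on the benzyl ring leaves compounds 3 and 4 alike.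

It stays open whether benzyl to 2-chlorobenzyl would also read within the scatter with methyl or methoxy on the aryl, since the only plain benzyl compound shown carries chloro there. Also open, on these data alone, is how the series would read in this assay with an amine, a carboxylic acid or a longer alkyl chain on the aryl in place of methyl, methoxy or chloro.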